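The compounds below may be only part of what the source reports. "The series", "measured", "known", "first", "only" and "open" are said of these compounds alone.

In a functional assay on HEK293 cells for agonist activity at probable G-protein coupled receptor 27 (Homo sapiens), read by a luciferase reporter and beta-arrestin recruitment, with a stated time of 10 min (on this read-out higher numbers stand for larger maximal responses and lower numbers for smaller maximal responses), four compounds of a shared core are considered. Compound 1 `CN(c1ccccc1)S(=O)(=O)c1ccc(NC(=O)c2ccc(Cl)cc2Cl)cc1` gives 50% in this assay. Compound 2 `O=C(Nc1ccc(S(=O)(=O)Nc2ccccc2)cc1)c1ccc(Cl)cc1Br` gives 123% in this assay, a larger maximal response than compound 1 shows. Within the data shown here, compound 3 `O=C(NS(=O)(=O)c1ccc(NC(=O)c2ccc(Cl)cc2Cl)cc1)c1ccccc1` carries a benzoyl group on the sulfonamide nitrogen; for compound 3 the entry in this assay reads "not determined" (no result reported), so compound 3 stands without a number and no step can be sized from it.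

Compound 4 `O=C(Nc1ccc(S(=O)(=O)Nc2ccccc2)cc1)c1ccc(Cl)cc1Cl` is the next member. The change from compound 3 to compound 4 is phenyl in place of benzoyl on a sulfonamide nitrogen. Since compound 3 has no value, the direction of the step to compound 4 in this assay cannot be judged against the usual scatter; the expectation rests on the other two compounds. Compound 4 shares the dichlorinated benzamide of compound 1 and the plain anilino sulfonamide of compound 2, and compound 2 gives 123%. Compound 4 is therefore expected to give about 100% in this assay, with an estimated range from 60% to 135%.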

Compound 4, largest response reached (Emax), in percent of the reference or control that the assay uses: 100%
Compound 4: middle estimate and measured number agree at the digits printed; the measured number falls inside the stated range.
By their numbers in this assay, from the lowest: compound 1; then compound 4; then compound 2.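

In this assay, compound 4 gives both places a measured step: hydrogen in place of methyl on a sulfonamide nitrogen is a number 50 percentage points higher from compound 1 to compound 4 (beyond the scatter), and chloro in place of bromo on an aromatic carbon is a number 23 percentage points lower from compound 2 to compound 4 (beyond the scatter), so each change alters the maximal response beyond the scatter. The step between compound 3 and compound 4 cannot be read, since compound 3 has no number. Nothing given here accounts for either measured step.

The compounds shown leave open how an ethyl chain on the sulfonamide nitrogen would compare with methyl and hydrogen. They also leave open whether fluoro or iodo on that aromatic carbon would follow the change from bromo to chloro, and whether the two steps would hold on other members of the series.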